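Halogen pattern swap on the aromatic nitrogen substituent

This account rests on a few compounds, and the source may have more. Where it says the series, first, only, none or still open, it means among the compounds named here.

Values in a functional assay on HepG2 cells (Homo sapiens) for inhibition, read by MTT assay, with a stated time of 72 h (a higher number here means a weaker inhibitor, a lower number a stronger inhibitor), so far:
compound 1 `O=C(Nc1ccc(Oc2ccnc3[nH]ccc23)cc1)c1cn(-c2ccccc2)c2ccccc2c1=O`: 2250 nM
compound 2 `O=C(Nc1ccc(Oc2ccnc3[nH]ccc23)cc1)c1cn(-c2ccc(Br)cc2F)c2ccccc2c1=O`: 790 nM

Compound 2 holds the lower of the two numbers; the step of a 2.8-fold lower number from compound 1 to compound 2 (0.45 log units; beyond the scatter) lies beyond the scatter. Compound 3 `O=C(Nc1ccc(Oc2ccnc3[nH]ccc23)cc1)c1cn(-c2ccc(F)c(Cl)c2)c2ccccc2c1=O` differs from compound 2 by 3-chloro-4-fluorophenyl in place of 4-bromo-2-fluorophenyl on an aromatic nitrogen. Among the compounds with values here, the only measured step on this position, a 2.8-fold lower number from compound 1 to compound 2 (0.45 log units; beyond the scatter), compares an unsubstituted phenyl with a halogenated one; no step compares two halogen patterns. Compound 3 keeps a dihalogenated phenyl, so the expected shift a 1.3-fold higher number from compound 2 to compound 3 (0.10 log units; within the scatter) is small, likely within the scatter. Compound 3 is estimated at 1000 nM, with a range from 400 nM to 2500 nM.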

Compound 3, half-maximal inhibitory concentration: 1120 nM
Beside the measured number, compound 3's estimate is 1.1-fold (0.05 log units) below it; measured number inside the range.
By their numbers in this assay, from the lowest: compounds 2, 3 and 1 (each within the scatter of the next, the first and the last beyond it).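

In this assay, exchanging one dihalogenated phenyl for the other on the aromatic nitrogen stays within the scatter (a 1.4-fold higher number from compound 2 to compound 3 (0.15 log units; within the scatter)), so these two halogen patterns are not told apart. The 3-chloro-4-fluorophenyl group is also not separated from plain phenyl (a 2.0-fold lower number from compound 1 to compound 3 (0.30 log units; within the scatter)), so halogenation as such does not give a step beyond the scatter: only 4-bromo-2-fluorophenyl does, and compound 3 goes against any general halogen trend. No supporting data bear on this result.

Open, from the compounds shown here alone, is whether a methoxy group or an amine on this phenyl would give a larger step, and whether a short alkyl chain could replace the phenyl.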